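This account rests on a few compounds, and the source may have more. Where it says the series, first, only, none or still open, it means among the compounds named here.

Measured compounds:
compound 1, `CC1CCN(C(=S)SCc2ccc(C(=O)Nc3ccccc3N)cc2)CC1`: 87.4%
compound 2, `Nc1ccccc1NC(=O)c1ccc(CSC(=S)N2CCN(c3ccc(F)cc3)CC2)cc1`: 76.3%
compound 3, `Nc1ccccc1NC(=O)c1ccc(CSC(=S)N(Cc2ccccc2)Cc2ccccc2)cc1`: 32.5%

All three numbers come from a functional assay on A-375 cells (Homo sapiens) for antiproliferative activity, read by CCK-8 assay, with a stated time of 72 h, tested at 8 uM; a lower number here means a weaker effect, a higher number a stronger effect of the compound at the concentration tested. Compound 2 holds the second highest of the three numbers. Its nearest neighbour is compound 1, whose number is higher by a margin beyond the usual scatter; its furthest is compound 3, whose number is far lower, again beyond the scatter. Going by the values given here, the three measured compounds differ from each other in more than one place, so no single step between measured compounds is available.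

Compound 4, `N#Cc1ccc(N2CCN(C(=S)SCc3ccc(C(=O)Nc4ccccc4N)cc3)CC2)cc1`, has not yet been measured in this assay. It differs from compound 2 in one place: cyano in place of fluoro on an aromatic carbon. Among the compounds with values here, no measured pair shows the effect of cyano in place of fluoro on an aromatic carbon, so the expectation rests on the change alone. The expected step is a number 4.3 percentage points lower from compound 2 to compound 4 (within the scatter), that is, none beyond the scatter or at most a slight fall. Compound 4 is thus expected to give 72% in this assay, within a range from 55% to 88%.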

Compound 4, a percentage reported as inhibition, at one concentration (the size of the read-out at that concentration, not a potency): 62.9%
For compound 4 the middle estimate is 9.1 percentage points above the measured one; the measured number falls inside the stated range.
By their numbers in this assay, from the lowest: compound 3; then compound 4; then compound 2; then compound 1.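

In this assay the series now has one single-place comparison, and it gives a number 13.4 percentage points lower from compound 2 to compound 4 (beyond the scatter) for 4-fluorophenyl changed to 4-cyanophenyl. Going by these compounds alone, the substituent on this aromatic carbon, para to a large group, therefore affects the read-out at the concentration tested, which the earlier compounds could not show because they differ from each other in more than one place. No available data explain this fall.

A single pair gives the direction for this one exchange only and sets no trend across substituents at this position. From the compounds shown here alone, it remains open how chloro, methoxy, an amine or a carboxylic acid on the same aromatic carbon would compare, and whether the fall from fluoro to cyano would recur on a different amine portion of the core.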